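Will the chloro compound give a number?

The source may report more compounds than this note shows. Statements on the series, on what has been measured and on what is new or still open speak of the compounds shown alone.

Among the compounds with values here, in a functional assay on the whole organism (strain Kunming) with Mus musculus as the target, with a stated time of 0.5 h (on this read-out higher numbers stand for an effect only at larger amounts of compound and lower numbers for an effect already at smaller amounts), compound 3 `COc1cccc(/C=C/C(=O)OC/C=C/c2cc(OC)c(OC)cc2OC)c1` gives 647 umol/kg, the only actual number among the three compounds measured. Compound 1 `COc1cc(OC)c(OC)cc1/C=C/COC(=O)/C=C/c1ccc(Br)cc1` gives only a limit, > 692 umol/kg. Compound 2 `COc1cc(OC)c(OC)cc1/C=C/COC(=O)/C=C/c1ccc(F)cc1` also gives only a limit, > 805 umol/kg.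

Compound 4 `COc1cc(OC)c(OC)cc1/C=C/COC(=O)/C=C/c1ccc(Cl)cc1` is still unmeasured. Its difference from compound 3 is 4-chlorophenyl in place of 3-methoxyphenyl on a double-bonded chain carbon bound to a double-bonded chain carbon, with 4-chlorophenyl in place of 3-methoxyphenyl.

Compound 4 resembles compound 1 with its 4-bromophenyl and compound 2 with its 4-fluorophenyl, so the steps into compound 3 are the best guide when read backwards: an at least 1.0-fold lower number from compound 1 to compound 3 (0.02 log units; that floor lies within the scatter) and an at least 1.2-fold lower number from compound 2 to compound 3 (0.09 log units; that floor lies within the scatter). Both are minimum sizes, so the true steps could be larger. The step between the two relatives, a step that the two limits leave unreadable from compound 1 to compound 2, adds nothing further.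

A slightly higher number is therefore expected, and the result may well be another limit. The expected step is a 1.2-fold higher number from compound 3 to compound 4 (0.08 log units; within the scatter), which stays within the scatter. Compound 4 is estimated at 780 umol/kg, with an expected range from 480 umol/kg to 1250 umol/kg.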

Compound 4, dose for half-maximal effect: > 514 umol/kg
Compound 4 ended at the assay's limit; the forecaster's own chance of this, stated with the estimate: 65%; the middle value lies beyond the limit too.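

Compound 4 ends at a limit, like compound 1 and compound 2, so its steps to compound 1, compound 2 and compound 3 cannot be read. The compounds shown leave open where the true numbers of these three limit compounds lie in this assay, and whether the bromo, fluoro and chloro compounds differ at all.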